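A few compounds are considered here, and "the series" means these few. Any claim that something is new, unique, unknown or untested is made for them only; others in the source may bear on it.

Measured compounds:
- compound 1 `COc1cc(-c2cc(/C=C/C(=O)c3ccc(N)cc3)[nH]n2)cc(OC)c1OC`: 105%
- compound 2 `COc1ccc(C(=O)/C=C/c2cc(-c3cc(OC)c(OC)c(OC)c3)n[nH]2)cc1OC`: 96%

Both numbers come from a functional assay on OVCAR-4 cells (Homo sapiens) for cytotoxicity, read by sulforhodamine B assay, with a stated time of 48 h, tested at 0.1 uM; a higher number here means a weaker effect of the compound at the concentration tested, a lower number a stronger effect. In this assay compound 1 gives 105%, and compound 2 gives 96%. Going by the values given here, the only measured step, a number 9 percentage points lower from compound 1 to compound 2 (within the scatter), joins these two, so compound 2 stands together with compound 1 inside the usual scatter, and neither number can be called different from the other.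

Compound 3 is `COc1cc(C(=O)/C=C/c2cc(-c3cc(OC)c(OC)c(OC)c3)n[nH]2)cc(OC)c1OC`. It differs from compound 2 by methoxy in place of hydrogen on an aromatic carbon; the new group sits on a six-membered aromatic ring of carbon only, ortho to a methoxy group and meta to a methoxy group and to a large group. Among the compounds with values here, no measured step involves adding a methoxy group, so nothing among the two compounds bears directly on this change. Within the data shown here, the single step on record, a number 9 percentage points lower from compound 1 to compound 2 (within the scatter), replaced a whole aryl group on the carbonyl carbon and still stayed within the scatter. With no evidence for movement, the expected step of a number 1 percentage points lower from compound 2 to compound 3 (within the scatter) is none beyond the scatter. Compound 3 is therefore estimated at 95%, within a range of 80% to 110%.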

Compound 3, a percentage reported as activity, at one concentration (the size of the read-out at that concentration, not a potency): 95%
For compound 3 middle estimate and measured number coincide at the digits printed; the measured number falls inside the stated range.
By their numbers in this assay, from the lowest: compounds 3, 2 and 1 (each within the scatter of the next).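

Placing a methoxy group on this aromatic carbon, ortho to a methoxy group and meta to a methoxy group and to a large group, gives a number 1 percentage points lower from compound 2 to compound 3 (within the scatter) in this assay. Going by these compounds alone, the one earlier step exchanged a whole aryl group on the carbonyl carbon, whereas this step adds a single small group to an aryl ring that stays in place, so it is the first direct reading of such an addition. At this position and at this one test concentration, the added methoxy group produces no change that can be told apart from the usual scatter, and no further measurement offers any explanation for this result.

From the compounds shown here alone, it remains open whether a different group on the same carbon, such as a hydroxyl group or a carboxylic acid, would move the read-out beyond the scatter. A reading at a single concentration is also not a potency, so these numbers leave open whether compound 2 and compound 3 would still match at other concentrations.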